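Adding Fluoro to the 3-Bromophenyl Compound

A few compounds are considered here, and "the series" means these few. Any claim that something is new, unique, unknown or untested is made for them only; others in the source may bear on it.

Compound 1 `COc1ccc(NC(=O)C2CCN(C/C=C/c3ccccc3)CC2)cc1`: > 100000 nM (a limit of the assay, not a number)
Compound 2 `COc1cccc(NC(=O)C2CCN(C/C=C/c3ccccc3)CC2)c1`: 42700 nM
Compound 3 `O=C(Nc1cccc(Br)c1)C1CCN(C/C=C/c2ccccc2)CC1`: 11500 nM

In a functional assay on MCF7 cells (Homo sapiens) for inhibition, read by MTT assay, with a stated time of 72 h (a higher number here means a weaker inhibitor, a lower number a stronger inhibitor), compound 3 gives 11500 nM, the lowest number of the three and the strongest inhibition. Compound 4 `O=C(Nc1ccc(F)c(Br)c1)C1CCN(C/C=C/c2ccccc2)CC1` differs from compound 3 by fluoro in place of hydrogen on an aromatic carbon, ortho to a bromo group. Going by the values given here, no measured step adds fluoro. The nearest guides swap whole groups and are modest: an at least 2.3-fold lower number from compound 1 to compound 2 (0.36 log units; beyond the scatter), an at least 8.6-fold lower number from compound 1 to compound 3 (0.93 log units; beyond the scatter) and a 3.7-fold lower number from compound 2 to compound 3 (0.57 log units; beyond the scatter). Since compound 4 keeps the bromo group and changes less than any of these, little change is expected in this assay, with no clear direction. The expected result is a 1.2-fold lower number from compound 3 to compound 4 (0.06 log units; within the scatter). The estimate for compound 4 is 10000 nM, with an expected range of 4000 nM to 28000 nM.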

Compound 4, half-maximal inhibitory concentration: 13500 nM
Beside the measured number, compound 4's estimate is 1.4-fold (0.13 log units) below it; the range from low to high includes it.
By their numbers in this assay, from the lowest: compounds 3 and 4 (each within the scatter of the next); then compound 2. At a limit, above all of these: compound 1.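

In this assay, fluoro on this aromatic carbon, ortho to a bromo group, gives a 1.2-fold higher number from compound 3 to compound 4 (0.07 log units; within the scatter), so this added atom leaves compound 3 and compound 4 indistinguishable. Replacing 3-methoxyphenyl with 3-bromo-4-fluorophenyl gives a 3.2-fold lower number from compound 2 to compound 4 (0.50 log units; beyond the scatter), a gap still beyond the scatter with fluoro present. The step of an at least 7.4-fold lower number from compound 1 to compound 4 (0.86 log units; beyond the scatter) is only a bound, since compound 1 stands at a limit of the assay: the limit of > 100000 nM in this assay, at which 1 of the 4 values shown sits.

As far as these compounds go, whether an amine or a carboxylic acid at this same position would also stay within the scatter of compound 3 remains open.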